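The compounds below may be only part of what the source reports. "The series", "measured", "known", "first", "only" and "open" are said of these compounds alone.

Working notes on the series: in an ADME assay on microsomes from liver (Homo sapiens) for metabolic stability (a lower number here means that the compound disappears faster, a higher number that the compound lasts longer), compound 3 `CC#C[C@@H](Cc1nnn[nH]1)c1ccc(OCc2ccc3scc(C4CC4)c3c2)cc1` gives 0.267 h, the lowest of the three numbers so far, against compound 1 `CC#C[C@@H](Cc1nnn[nH]1)c1ccc(OCc2ccc3scc(-c4cc(OCCOC)ccc4C)c3c2)cc1` at 0.867 h and compound 2 `CC#C[C@@H](Cc1nnn[nH]1)c1ccc(OCc2ccc3scc(-c4ccc(OCCOC)cc4C)c3c2)cc1` at 0.717 h. The two phenyl-bearing compounds show a 1.2-fold lower number from compound 1 to compound 2 (0.08 log units; within the scatter). The change under consideration leads to compound 4 `CC#C[C@@H](Cc1nnn[nH]1)c1ccc(OCc2ccc3scc(-c4ccccc4C(F)(F)F)c3c2)cc1`: 2-(trifluoromethyl)phenyl in place of cyclopropyl on an aromatic carbon. For the measured compounds named here, two measured steps bear on it, a 3.2-fold lower number from compound 1 to compound 3 (0.51 log units; beyond the scatter) and a 2.7-fold lower number from compound 2 to compound 3 (0.43 log units; beyond the scatter), both with cyclopropyl entering in place of a substituted phenyl. Read in reverse, they point to a modest rise in this assay, although neither measured phenyl group carries trifluoromethyl. The expected step is a 2.8-fold higher number from compound 3 to compound 4 (0.45 log units; beyond the scatter). The estimate for compound 4 is 0.75 h, with an expected range of 0.38 h to 1.5 h.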

Compound 4, half-life: < 0.0667 h
Compound 4: a limit, no number (the forecaster's own chance of this, stated with the estimate: 3%); middle value at least 11-fold (1.05 log units) away from the limit.
By their numbers in this assay, from the lowest: compound 3; then compounds 2 and 1 (each within the scatter of the next). At a limit, below all of these: compound 4.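

In this assay compound 4 gives a limit, not a number: the limit of < 0.0667 h in this assay, at which 1 of the 4 values shown sits. At this aromatic carbon, two ring bonds from the ring sulfur, 2-(trifluoromethyl)phenyl in place of cyclopropyl gives an at least 4.0-fold lower number from compound 3 to compound 4 (0.60 log units; beyond the scatter), so a phenyl group does not by itself raise the number. Against the two phenyl groups bearing 2-methoxyethoxy, the same position shows an at least 10-fold lower number from compound 2 to compound 4 (1.03 log units; beyond the scatter) and an at least 12-fold lower number from compound 1 to compound 4 (1.11 log units; beyond the scatter), so the choice of phenyl group here can move the number in either direction.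

Still open, as far as these compounds go, is whether the fall follows the trifluoromethyl group or the absence of the 2-methoxyethoxy chain. Unsubstituted phenyl or 2-methylphenyl at this carbon would separate the two.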